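Notes on the cyclopropane amide series at the receptor

The source may hold more compounds than are shown below. What is called first, only, known or untested is meant among the compounds shown, and "the series" means these compounds.

Within the data shown here, compound 1 `CC(C)CCCN(C(=O)[C@@H]1C[C@H]1c1ccccc1)c1ccc(-c2ccccc2)cc1` is the first member. In a functional assay for agonist activity at G protein-coupled receptor 88 (Homo sapiens), read by HTRF and cAMP accumulation (a lower number here means that less compound is needed, a higher number that more compound is needed for the effect), compound 1 gives only a limit, > 100 nM, with no number behind it. Among the measured compounds shown here, compound 2 `CC[C@H](C)[C@H](N)CN(C(=O)[C@@H]1C[C@H]1c1cc(F)ccc1F)c1ccc(-c2ccccc2)cc1` carries the 2,5-difluorophenyl on the three-membered ring and is the only compound with a numerical value: in this assay compound 2 gives 770 nM. For the measured compounds named here, the other value sits at the limit of > 100 nM in this assay, at which 1 of the 2 values shown sits, so no measured step can be drawn from it.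

Compound 3 `CC[C@H](C)[C@H](N)CN(C(=O)[C@@H]1C[C@H]1c1ncc(C)s1)c1ccc(-c2ccccc2)cc1` is the next analogue, not yet measured. It differs from compound 2 in one place: 5-methyl-1,3-thiazol-2-yl in place of 2,5-difluorophenyl on a saturated ring carbon. Going by the values given here, no pair of measured compounds shows this kind of exchange, so the direction is open. The expectation is a step that stays close to the scatter, a 1.6-fold higher number from compound 2 to compound 3 (0.19 log units; within the scatter), with a broad range on either side. Compound 3 is estimated at 1200 nM, between 300 nM and 5000 nM.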

Compound 3, half-maximal effective concentration: 1300 nM
For compound 3 the middle estimate is 1.1-fold (0.03 log units) below the measured one; measured number inside the range.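

In this assay, among these compounds, the exchange on the saturated ring carbon of the cyclopropane gives a 1.7-fold higher number from compound 2 to compound 3 (0.23 log units; within the scatter) and so supplies the first measured step at this position. A six-membered aromatic ring of carbon only and a five-membered aromatic ring with 2 hetero atoms can therefore stand here with values that remain within the scatter of each other, even though the entering group differs in its ring atoms and its hydrogen-bond acceptors. No measured property in the series bears on this result.

Still open, as far as these compounds go, is whether this holds for groups beyond these two, such as an unsubstituted phenyl, a pyridine, a thiazole without its methyl, or a carboxylic acid at the same carbon. The compounds shown also do not separate the contribution of the amine on the side chain, since no measured pair differs there alone.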